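Compound 2 to compound 3: capping the free hydroxy

This account rests on a few compounds, and the source may have more. Where it says the series, first, only, none or still open, it means among the compounds named here.

- compound 1 `O=C(/C=C/c1ccc(OCCCCCO[N+](=O)[O-])c(O)c1)OCCCCCO[N+](=O)[O-]`: > 50000 nM, a limit of the assay
- compound 2 `COc1cc(/C=C/C(=O)OCCCCCO[N+](=O)[O-])ccc1O`: 12500 nM

Among the compounds with values here, in a functional assay on HOP-62 cells (Homo sapiens) for cytotoxicity, read by resazurin assay, with a stated time of 72 h (on this read-out higher numbers stand for weaker inhibition and lower numbers for stronger inhibition), compound 2 gives 12500 nM, the only actual number so far. Compound 1 gives no number, only a limit: the limit of > 50000 nM in this assay, at which 1 of the 2 values shown sits.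

The next compound is compound 3 `COc1cc(/C=C/C(=O)OCCCCCO[N+](=O)[O-])ccc1OCCCCCO[N+](=O)[O-]`, which keeps the ester chain of compound 2 and changes one place: 5-(nitrooxy)pentyl in place of hydrogen on an oxygen on an aromatic ring. In words, 5-(nitrooxy)pentyl replaces hydrogen on an oxygen on an aromatic ring, so the hydroxy becomes (5-(nitrooxy)pentyl)oxy.

Compound 1 carries the same group on such an oxygen, and its > 50000 nM is a limit. It differs from compound 3 elsewhere as well, so this is a single, weak pointer. The direction expected in this assay is therefore towards weaker inhibition, with a real chance that the reading reaches the limit. The expected size is a 2.2-fold higher number from compound 2 to compound 3 (0.35 log units; beyond the scatter), which is only an estimate.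

For compound 3 the estimated value is 28000 nM, with an expected range of 10000 nM to 50000 nM.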

Compound 3, half-maximal inhibitory concentration: > 50000 nM
Compound 3 gave a limit, no number; the forecaster's own chance of this, stated with the estimate: 35%; at least 1.7-fold (0.25 log units) between middle value and limit.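

In this assay, within the data shown here, 5-(nitrooxy)pentyl in place of hydrogen on an oxygen on an aromatic ring gives an at least 4.0-fold higher number from compound 2 to compound 3 (0.60 log units; beyond the scatter), the first direct reading of this change, and it runs towards weaker inhibition. Compound 3 gives > 50000 nM, which is a limit of the assay, so the step has a lower bound and no upper one. The step between compound 1 and compound 3 cannot be read, and the series now offers little room for further comparison: the limit of > 50000 nM in this assay, at which 2 of the 3 values shown sit.

Still open, from the compounds shown here alone, is whether a small group on this oxygen, such as ethyl or acetyl, would leave the reading close to that of compound 2 or would also weaken it. Also open, going by these compounds, is whether the nitrooxy group matters to this loss or the chain alone is enough, a question that a plain pentyl group on the same oxygen would address.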